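Series notes: from compound 3 to compound 4

The compounds below may be only part of what the source reports. "The series", "measured", "known", "first", "only" and "open" are said of these compounds alone.

Compound 3 `O=C1NC(=O)/C(=C/c2ccc(OCCSc3nnc(-c4ccccc4[N+](=O)[O-])[nH]3)cc2)S1` gives 19.8% in a functional assay on the whole organism (strain Wistar) with Rattus norvegicus as the target, with a stated time of 15 days, at a dose of 3 mg/kg by the oral route; a lower number here means a weaker effect, a higher number a stronger effect of the compound at the dose given. Among the three measured compounds it stands second highest of the three numbers. Its nearest neighbour is compound 1 `Cc1ccc(-c2nnc(SCCOc3ccc(/C=C4\SC(=O)NC4=O)cc3)[nH]2)cc1`, which gives 25.2%, and the furthest is compound 2 `O=C1NC(=O)/C(=C/c2ccc(OCCSc3nnc(-c4ccc([N+](=O)[O-])cc4)[nH]3)cc2)S1`, which gives 14.1%; both gaps to compound 3 lie within the scatter (a number 5.4 percentage points lower from compound 1 to compound 3 (within the scatter); a number 5.7 percentage points higher from compound 2 to compound 3 (within the scatter)).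

Compound 4 `O=C1NC(=O)/C(=C/c2ccc(OCCSc3nnc(-c4ccc(Cl)cc4)[nH]3)cc2)S1` differs from compound 3 by 4-chlorophenyl in place of 2-nitrophenyl on an aromatic carbon. Among the compounds with values here, the only measured step beyond the scatter is a number 11.1 percentage points lower from compound 1 to compound 2 (beyond the scatter). Within the data shown here, the two steps that involve the 2-nitrophenyl group are both within the scatter, and no measured step introduces a 4-chlorophenyl, so the closest guidance comes from compound 1 with its 4-methylphenyl and compound 2 with its 4-nitrophenyl, whose values bracket compound 3. The expected step is therefore a number 2.2 percentage points higher from compound 3 to compound 4 (within the scatter), nothing beyond the scatter, with a wide range to cover both neighbours. Compound 4 is expected at 22%, between 12% and 32%.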

Compound 4, a percentage reported as activity, at one dose (the size of the read-out at that dose, not a potency): 23.9%
The estimate for compound 4 lay 1.9 percentage points below the measured number; low and high end bracket the measured number.
By their numbers in this assay, from the lowest: compounds 2, 3, 4 and 1 (each within the scatter of the next, the first and the last beyond it).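

Chloro on the phenyl group at this position can now be read against three neighbours in this assay, and none of the new steps leaves the scatter: a number 4.1 percentage points higher from compound 3 to compound 4 (within the scatter), a number 9.8 percentage points higher from compound 2 to compound 4 (within the scatter) and a number 1.3 percentage points lower from compound 1 to compound 4 (within the scatter). Chloro in place of methyl and chloro in place of nitro both stay within the scatter, so compound 4 cannot be assigned to either end of the series, while a number 11.1 percentage points lower from compound 1 to compound 2 (beyond the scatter) remains the only step beyond it. The change of 2-nitrophenyl to 4-chlorophenyl, which alters both the group and where it carries its substituent, gives no separable difference in this read-out. No measurement offers an explanation for these numbers.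

From the compounds shown here alone, whether an amine or a carboxylic acid on the phenyl group would give a step beyond the scatter from compound 4 remains open. Also open, going by these compounds, is whether a longer chain in place of the one linking the shared core to the sulfur would alter the read-out in this assay.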